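The source may report more compounds than this note shows. Statements on the series, on what has been measured and on what is new or still open speak of the compounds shown alone.

Measured in a functional assay on A549 cells (Homo sapiens) for antiproliferative activity, read by MTT assay, with a stated time of 48 h; a lower number here means a stronger inhibitor, a higher number a weaker inhibitor:
Compound 1 `COc1ccc(/C=C/c2cc(OC)cc(OC)c2/C=C/C(=O)c2ccc(Cl)c(Cl)c2)cc1`: 5.9 ug/mL
Compound 2 `CCCC(C)Oc1ccc(C(=O)/C=C/c2c(/C=C/c3ccc(OC)cc3)cc(OC)cc2OC)cc1`: 9.4 ug/mL

Compound 2 sits within the usual scatter of compound 1, so these two numbers cannot be told apart. In compound 3 `COc1ccc(/C=C/c2cc(OC)cc(OC)c2/C=C/C(=O)c2ccc(C)cc2)cc1`, methyl takes the place of 1-methylbutoxy on an aromatic carbon, para to a large group: methyl in place of 1-methylbutoxy on an aromatic carbon. Within the data shown here, one measured step bears on this, a swap of the group on the same carbonyl carbon: a 1.6-fold higher number from compound 1 to compound 2 (0.20 log units; within the scatter). That step stayed within the scatter, so no step beyond the scatter is expected in this assay, and no direction can be argued. The estimate amounts to a 1.3-fold lower number from compound 2 to compound 3 (0.10 log units; within the scatter). For compound 3 the expected value is 7.5 ug/mL, with an estimated range of 3.5 ug/mL to 16 ug/mL.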

Compound 3, half-maximal inhibitory concentration: 3.6 ug/mL
Compound 3: the middle estimate sits 2.1-fold (0.32 log units) above what was measured; the range from low to high includes it.
By their numbers in this assay, from the lowest: compounds 3, 1 and 2 (each within the scatter of the next, the first and the last beyond it).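

Among these compounds, measured in this assay the change from 1-methylbutoxy to methyl on this aromatic carbon gives a 2.6-fold lower number from compound 2 to compound 3 (0.42 log units; beyond the scatter) and so provides the first step here beyond the scatter, though a modest one. Replacing 3,4-dichlorophenyl with 4-methylphenyl gives a 1.6-fold lower number from compound 1 to compound 3 (0.21 log units; within the scatter) and stays within the scatter, so those two groups cannot be told apart. Nothing available explains the result.

The compounds shown leave open whether the step follows the oxygen or the length of the chain. A methoxy or a butyl group at this place would separate the two.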